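Aryl variation on the shared core: compound 4

The compounds below may be only part of what the source reports. "The series", "measured", "known", "first", "only" and "open" are said of these compounds alone.

Measured compounds:
compound 1 `c1ccc2c(-c3cn4ccnc4c(-c4ccc5ncn(C6CCCCC6)c5c4)n3)cccc2c1` gives 10.4%
compound 2 `CC(=O)c1ccc(-c2cn3ccnc3c(-c3ccc4ncn(C5CCCCC5)c4c3)n2)cc1` gives 0.73%
compound 3 `Clc1ccc(-c2cn3ccnc3c(-c3ccc4ncn(C5CCCCC5)c4c3)n2)cc1` gives 10.6%

All three numbers come from a functional assay on MDA-MB-468 cells (Homo sapiens) for inhibition, read by sulforhodamine B assay, with a stated time of 48 h, tested at 10 uM; on this read-out lower numbers stand for less inhibition and higher numbers for more inhibition at the one concentration tested (going by the name of the read-out). Compound 3 lies within the scatter of both other compounds: a number 0.2 percentage points higher from compound 1 to compound 3 (within the scatter) and a number 9.9 percentage points higher from compound 2 to compound 3 (within the scatter). The remaining pair is likewise flat, with a number 9.7 percentage points lower from compound 1 to compound 2 (within the scatter). Each of these three steps exchanges the aryl group on the same aromatic carbon of the shared core, and none of them moves the read-out beyond the scatter.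

Compound 4 `COc1ccccc1-c1cn2ccnc2c(-c2ccc3ncn(C4CCCCC4)c3c2)n1` has not yet been measured. It differs from compound 3 by 2-methoxyphenyl in place of 4-chlorophenyl on an aromatic carbon. Going by the values given here, the steps that bear on this change are the three aryl exchanges above, each within the scatter. Among the compounds with values here, no measured compound carries a methoxy group, so the evidence for this particular substituent is indirect; what is known is that three different aryl groups at this position gave numbers that cannot be told apart.

On that basis the expected step of a number 0.6 percentage points lower from compound 3 to compound 4 (within the scatter) is none beyond the scatter. Compound 4 is therefore estimated at 10%, with an expected range from 0% to 25%.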

Compound 4, a percentage reported as inhibition, at one concentration (the size of the read-out at that concentration, not a potency): 14.6%
Estimate against measurement, compound 4: 4.6 percentage points below; measured number inside the range.
By their numbers in this assay, from the lowest: compounds 2, 1, 3 and 4 (each within the scatter of the next, the first and the last beyond it).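

In this assay, going by these compounds alone, the step of a number 13.9 percentage points higher from compound 2 to compound 4 (beyond the scatter) is the first exchange at this aromatic carbon to pass beyond the scatter, though only modestly, so the choice of aryl group here is not entirely without consequence for the read-out. That separation holds for this one pair only, since 2-methoxyphenyl cannot be told apart from 4-chlorophenyl (step a number 4 percentage points higher from compound 3 to compound 4 (within the scatter)) or from naphthalen-1-yl (step a number 4.2 percentage points higher from compound 1 to compound 4 (within the scatter)), which leaves no order among compounds 1, 3 and 4, and compound 2 remains within the scatter of compounds 1 and 3. Nothing available explains the gap between the 4-acetylphenyl and 2-methoxyphenyl groups.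

The compounds shown cannot separate the effect of the methoxy group from that of where it sits on the ring, a question that 4-methoxyphenyl or 3-methoxyphenyl would address directly. Also open, going by these compounds, is whether an aryl group carrying an amine such as morpholine or a carboxylic acid would move the read-out further, and whether anything other than cyclohexyl on the shared core would change this picture.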